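Swapping the Sulfonyl Aryl: Cytotoxicity Outlook for Compound 3

The compounds below may be only part of what the source reports. "The series", "measured", "known", "first", "only" and "open" are said of these compounds alone.

Compound 1 `C=Cc1ccc(S(=O)(=O)Nc2ccc3oc(-c4ccccc4)nc3c2)cc1`: 53000 nM
Compound 2 `O=S(=O)(Nc1ccc2oc(-c3ccccc3)nc2c1)c1ccc(C(F)(F)F)cc1`: 74000 nM

Of the compounds shown here, two sharing one core have been measured in an ADME assay on HEK293 cells (Homo sapiens) for cytotoxicity, read by resazurin assay, with a stated time of 48 h; on this read-out higher numbers stand for lower toxicity in this test and lower numbers for higher toxicity in this test; compound 1 gives 53000 nM and compound 2 gives 74000 nM. Of the two numbers, compound 1 holds the lower one, but the step of a 1.4-fold higher number from compound 1 to compound 2 (0.14 log units; within the scatter) is within the scatter, so the two are not distinguishable on this read-out.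

Compound 3 `O=S(=O)(Nc1ccc2oc(-c3ccccc3)nc2c1)c1ccc(Cl)s1` is not yet measured. It differs from compound 1 at the sulfonyl sulfur: 5-chlorothiophen-2-yl in place of 4-vinylphenyl on a sulfonyl sulfur.

Among the compounds with values here, the only measured step that bears on this, the one at the same position from compound 1 to compound 2, was a 1.4-fold higher number from compound 1 to compound 2 (0.14 log units; within the scatter) and stayed within the scatter. On that basis compound 3 is expected to show no step beyond the scatter in this assay, that is no change at the digits printed from compound 1 to compound 3 (within the scatter). The estimate for compound 3 is 53000 nM, with a range from 20000 nM to 130000 nM.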

Compound 3, half-maximal cytotoxic concentration: > 100000 nM
Compound 3: only a limit was reported; the forecaster's own chance of this, stated with the estimate: 15%; middle value at least 1.8-fold (0.27 log units) away from the limit.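

In this assay compound 3 gives > 100000 nM, which is a limit of the assay and not a number. The step is an at least 1.8-fold higher number from compound 1 to compound 3 (0.27 log units; that floor lies within the scatter), so on this floor a five-membered aromatic ring with 1 hetero atom, 5-chlorothiophen-2-yl, can take the place of the six-membered carbon ring of 4-vinylphenyl on a sulfonyl sulfur without a lower number appearing, which compound 2, still built on a six-membered ring, could not show. The reading gives a floor for this change and not its size: the limit of > 100000 nM in this assay, at which 1 of the 3 values shown sits.

The compounds shown do not separate what the chlorine and the five-membered ring each contribute to this result. They also leave open how this read-out would respond to an amine or a carboxylic acid on the ring at this place.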